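The compounds below may be only part of what the source reports. "The series", "measured", "known", "first", "only" and "open" are said of these compounds alone.

Compound 1, with structure `CC(C)(C)NC(=O)N1CC1C#N`, is the weakest of three compounds tested in a functional assay on OVCAR-3 cells (Homo sapiens) for inhibition; on this read-out lower numbers stand for stronger inhibition and higher numbers for weaker inhibition: compound 1 gives 186000 nM, the highest number of the set, and its step to every other compound lies beyond the scatter. Compound 2, with structure `N#CC1CN1C(=O)Nc1cccc2ccccc12`, gives 5900 nM in this assay, and compound 3, with structure `N#CC1CN1C(=O)Nc1cccnc1`, gives 10000 nM. Both carry an aromatic ring on the urea nitrogen where compound 1 carries a tert-butyl group, and both sit far lower on the scale.

Compound 4, with structure `CNC(=O)N1CC1C#N`, has not yet been measured. It differs from compound 1 in one place: methyl in place of tert-butyl on an amide-type nitrogen. Within the data shown here, no measured pair in this set shows the effect of such an exchange. Starting from the weak inhibition of compound 1 at 186000 nM, the step from compound 1 to compound 4 is expected to be a 1.2-fold higher number from compound 1 to compound 4 (0.07 log units; within the scatter), that is, no change beyond the scatter. Compound 4 is therefore estimated at 220000 nM, within a range of 70000 nM to 700000 nM.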

Compound 4, half-maximal inhibitory concentration: 14000 nM
Compound 4: the middle estimate sits 16-fold (1.20 log units) above what was measured; the measured number lies below the stated range.
By their numbers in this assay, from the lowest: compounds 2, 3 and 4 (each within the scatter of the next, the first and the last beyond it); then compound 1.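

In this assay, exchanging tert-butyl for methyl on this amide-type nitrogen gives a 13-fold lower number from compound 1 to compound 4 (1.12 log units; beyond the scatter), so this position responds strongly to the choice of alkyl group. The earlier compounds shown here could not show this: compounds 2 and 3 carry aromatic rings at this position, which left open whether a ring was needed for lower numbers, whereas compound 4 reaches a low number with methyl and no ring. Nothing available here explains why this exchange has so large an effect.

As far as these compounds go, with only methyl and tert-butyl to compare among the simple alkyl groups, it remains open how ethyl or isopropyl would behave at this position. From the compounds shown here alone, it is also open whether a longer chain ending in an amine or a carboxylic acid would fit the same picture.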